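The compounds below may be only part of what the source reports. "The series", "measured", "known", "first", "only" and "open" are said of these compounds alone.

Of the compounds shown here, three sharing one core have been tested in a functional assay on A-375 cells (Homo sapiens) for antiproliferative activity, read by CCK-8 assay, with a stated time of 72 h, tested at 2 uM; on this read-out lower numbers stand for a weaker effect and higher numbers for a stronger effect at the one concentration tested. Compound 1 `Nc1ccccc1NC(=O)c1ccc(CSC(=S)N2CCN(c3cccnc3)CC2)cc1` gives 40.5%, and compound 2 `N#Cc1ccc(N2CCN(C(=S)SCc3ccc(C(=O)Nc4ccccc4N)cc3)CC2)cc1` gives 41.4%; the difference between them, a number 0.9 percentage points higher from compound 1 to compound 2 (within the scatter), is within the scatter. Compound 3 `Nc1ccccc1NC(=O)c1ccc(CSC(=S)N2CCN(c3ccccc3F)CC2)cc1` gives 18.7%, the lowest of the three numbers, and both steps leading to it are beyond the scatter: a number 21.8 percentage points lower from compound 1 to compound 3 (beyond the scatter) and a number 22.7 percentage points lower from compound 2 to compound 3 (beyond the scatter).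

The next compound, compound 4 `Nc1ccccc1NC(=O)c1ccc(CSC(=S)N2CCN(Cc3ccccc3)CC2)cc1`, differs from compound 3 in one place: benzyl in place of 2-fluorophenyl on an amine nitrogen in a ring. The two measured steps that bear on this position both show that exchanging the group on the ring nitrogen for 2-fluorophenyl lowered the read-out by a modest amount. For the measured compounds named here, no measured step involves benzyl, so the size of the return is uncertain, but a modest rise in this assay is expected, with a number 13.3 percentage points higher from compound 3 to compound 4 (beyond the scatter) as the estimated step. Compound 4 is therefore expected to give about 32% in this assay, within a range from 15% to 50%.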

Compound 4, a percentage reported as inhibition, at one concentration (the size of the read-out at that concentration, not a potency): 10.6%
For compound 4 the middle estimate is 21.4 percentage points above the measured one; the measured number lies below the stated range.
By their numbers in this assay, from the lowest: compounds 4 and 3 (each within the scatter of the next); then compounds 1 and 2 (each within the scatter of the next).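

Benzyl on the ring nitrogen brings no recovery in this assay, where the change from 2-fluorophenyl is a number 8.1 percentage points lower from compound 3 to compound 4 (within the scatter), so these two groups cannot be told apart here. Set against the other two groups, benzyl stands clearly lower, with a number 30.8 percentage points lower from compound 2 to compound 4 (beyond the scatter) and a number 29.9 percentage points lower from compound 1 to compound 4 (beyond the scatter), which shows that the low read-out at this position is not confined to 2-fluorophenyl and that pyridin-3-yl and 4-cyanophenyl are the two groups with the higher numbers. No measurement at hand explains why these groups divide in this way.

From the compounds shown here alone, it remains open how plain phenyl on the ring nitrogen would compare with 2-fluorophenyl and 4-cyanophenyl. Where a longer chain such as phenylethyl would fall is equally open.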